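The compounds below may be only part of what the source reports. "The series", "measured", "known", "first", "only" and "open" are said of these compounds alone.

Within the data shown here, in an assay for inhibition of MAP kinase-interacting serine/threonine-protein kinase 1 (Homo sapiens), read by luminescence and ADP-Glo, with a stated time of 2 h (on this read-out higher numbers stand for weaker inhibition and lower numbers for stronger inhibition), compound 2 `O=c1ccc(-c2ccc3cn[nH]c3c2)cn1Cc1ccccc1` gives 315 nM, the higher of the two numbers measured so far. Its nearest neighbour is compound 1 `O=c1ccc(-c2ccc3cn[nH]c3c2)cn1Cc1ccccc1C(F)(F)F`, which in this assay gives 133 nM. Among the measured compounds shown here, the single step between them, a 2.4-fold higher number from compound 1 to compound 2 (0.37 log units; beyond the scatter), puts hydrogen where a trifluoromethyl stood on an aromatic carbon. Compound 3 `NC(=O)c1ccccc1Cn1cc(-c2ccc3cn[nH]c3c2)ccc1=O` has not yet been measured in this assay; it differs from compound 2 by carbamoyl in place of hydrogen on an aromatic carbon, the carbamoyl entering on an aromatic carbon of a six-membered aromatic ring of carbon only, ortho to a large group. For the measured compounds named here, the only measured step that bears on this change is the one from compound 1 to compound 2: it shows that a group rather than hydrogen at this same spot went with a modestly lower number. A carbamoyl is not a trifluoromethyl, so that step is only a rough guide. A modest move toward a lower number is nevertheless expected, a 2.0-fold lower number from compound 2 to compound 3 (0.29 log units; within the scatter). Compound 3 is estimated at 160 nM in this assay, with a likely range from 50 nM to 500 nM.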

Compound 3, half-maximal inhibitory concentration: 878 nM
Compound 3: middle estimate off by 5.5-fold (0.74 log units), on the low side; the whole stated range lies below it.
By their numbers in this assay, from the lowest: compound 1; then compound 2; then compound 3.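

In this assay carbamoyl in place of hydrogen on this aromatic carbon gives a 2.8-fold higher number from compound 2 to compound 3 (0.45 log units; beyond the scatter) and so shows that a group at this spot does not by itself go with a lower number. Exchanging the trifluoromethyl directly for carbamoyl gives a 6.6-fold higher number from compound 1 to compound 3 (0.82 log units; beyond the scatter) and places hydrogen in the middle of the three, with trifluoromethyl on the lower side and carbamoyl on the higher side, so what counts here is which group enters and not merely that one enters. Nothing among the data shown offers a reason for this difference between the two groups.

Going by these compounds, it remains open how other groups on this same aromatic carbon would read in this assay, such as a nitrile, a carboxylic acid, an amine or a methyl ester, and so whether carbamoyl and trifluoromethyl mark the ends of a wider spread or merely two points within it. Also open, on these data alone, is whether a carbamoyl carrying a methyl on its nitrogen would give a number closer to that of compound 2 or stay with that of compound 3.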